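Nitro in Place of Bromo: Estimating Tolerated Concentration for Compound 4

A few compounds are considered here, and "the series" means these few. Any claim that something is new, unique, unknown or untested is made for them only; others in the source may bear on it.

Of the compounds shown here, three sharing one core have been tested in an ADME assay on MT4 cells (Homo sapiens) for cytotoxicity, read by MTT assay; a higher number here means that more compound is tolerated, a lower number that less compound is tolerated. Compound 1 `NC(=S)N1Nc2onc(-c3ccccc3)c2C1c1ccc(Cl)cc1` gives 340 nM. Compound 2 `Cc1nc(N2Nc3onc(-c4ccccc4)c3C2c2ccc(Cl)cc2)sc1/N=N/c1ccccc1` gives 260 nM, and compound 3 `Cc1nc(N2Nc3onc(-c4ccccc4)c3C2c2ccc(Cl)cc2)sc1/N=N/c1ccc(Br)cc1` gives 390 nM. The number for compound 3 lies within the scatter of that for compound 1 and of that for compound 2, so none of the three can be set apart from the others in this assay.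

Among the measured compounds shown here, the one step between compounds that differ in a single place, a 1.5-fold higher number from compound 2 to compound 3 (0.18 log units; within the scatter), shows that bromo in place of hydrogen on an aromatic carbon left the read-out essentially unchanged.

Compound 4 `Cc1nc(N2Nc3onc(-c4ccccc4)c3C2c2ccc(Cl)cc2)sc1/N=N/c1ccc([N+](=O)[O-])cc1` differs from compound 3 by nitro in place of bromo on an aromatic carbon. For the measured compounds named here, no measured pair shows nitro in place of bromo, so the only guide is the small step seen for the bromo substitution itself and the closeness of all three measured numbers. Compound 4 is therefore expected to give 390 nM in this assay, with a range from 190 nM to 800 nM. The step this estimate means, no change at the digits printed from compound 3 to compound 4 (within the scatter), is expected to stay within the scatter.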

Compound 4, half-maximal cytotoxic concentration: 280 nM
The estimate for compound 4 lay 1.4-fold (0.14 log units) above the measured number, within the range that was stated.
By their numbers in this assay, from the lowest: compounds 2, 4, 1 and 3 (each within the scatter of the next).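

In this assay the change from 4-bromophenyl to 4-nitrophenyl gives a 1.4-fold lower number from compound 3 to compound 4 (0.14 log units; within the scatter) and nitro in place of hydrogen gives a 1.1-fold higher number from compound 2 to compound 4 (0.03 log units; within the scatter) so this place now holds three substituents, hydrogen, bromo and nitro, without a step beyond the scatter. The earlier compounds shown here showed this only for bromo, a single heavy atom with no hydrogen-bond acceptors, whereas nitro brings three heavy atoms and two hydrogen-bond acceptors to the same place, para to a large group. The data offer no measurement that would explain this outcome.

From the compounds shown here alone, whether an amine or a carboxylic acid at this place would also stay within the scatter remains open. So does the question of whether nitro would read the same at another carbon of this ring.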